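Dropping the Chloro Group: An Untested Analogue of Compound 1

This account rests on a few compounds, and the source may have more. Where it says the series, first, only, none or still open, it means among the compounds named here.

Compound 1 `O=C(Nc1cc(C(F)(F)F)cc(C(F)(F)F)c1)c1cc(Cl)c(-c2ccccc2)cc1O` was tested in a functional assay on Jurkat cells (Homo sapiens) for cytotoxicity, read by luminescence and CellTiter-Glo, with a stated time of 3 days (on this read-out lower numbers stand for stronger inhibition and higher numbers for weaker inhibition), where compound 1 gives 540 nM. For the measured compounds named here, the only other measured compound, compound 2 `O=C(Nc1ccc(OC(F)(F)F)cc1)c1cc(F)ccc1O`, in this assay gives 810 nM. Compound 1 holds the lower of the two numbers, but the gap to compound 2 lies within the scatter, so the two values cannot be placed in order. Going by the values given here, no step between two measured compounds that differ in a single place is available, and the two compounds differ in several places at once. Compound 3 `O=C(Nc1cc(C(F)(F)F)cc(C(F)(F)F)c1)c1ccc(-c2ccccc2)cc1O` has not yet been measured. It differs from compound 1 by hydrogen in place of chloro on an aromatic carbon. Among the compounds with values here, with no measured step to lean on, the step of a 1.5-fold higher number from compound 1 to compound 3 (0.17 log units; within the scatter) in this assay is expected to be small, hardly beyond the scatter, and if anything toward a higher number. For compound 3 the estimate in this assay is 800 nM, with a range from 300 nM to 2500 nM.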

Compound 3, half-maximal inhibitory concentration: 1240 nM
Beside the measured number, compound 3's estimate is 1.6-fold (0.19 log units) below it; the measured number falls inside the stated range.
By their numbers in this assay, from the lowest: compounds 1, 2 and 3 (each within the scatter of the next, the first and the last beyond it).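

In this assay, the chloro group on this aromatic carbon, ortho to a phenyl group and para to a hydroxy group, proves to matter: hydrogen in its place gives a 2.3-fold higher number from compound 1 to compound 3 (0.36 log units; beyond the scatter), a modest step but one beyond the scatter. For the compounds shown here, this is the first comparison here between compounds that differ in one place, and so the first sign that this position responds to a change at all, though it rests on a single pair. Nothing available explains why the number moves.

The compounds shown leave open whether another group on this carbon, such as fluoro, methyl or an amine, would match the number of compound 1, improve on it or fall short of it. They also leave open whether swapping chloro for hydrogen would give a step of similar size if a different group replaced the phenyl group.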